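The source may hold more compounds than are shown below. What is called first, only, known or untested is meant among the compounds shown, and "the series" means these compounds.

In a functional assay on K562 cells (Homo sapiens), read by MTT assay, with a stated time of 72 h (a lower number here means a stronger inhibitor, a higher number a weaker inhibitor), compound 1 `CSc1ncnc2c1c(-c1ccsc1)cn2[C@@H]1O[C@H](CO)[C@@H](O)[C@H]1O` gives 450 nM. Compound 2 `Nc1nc(N)c2c(-c3ccco3)cn([C@@H]3O[C@H](CO)[C@@H](O)[C@H]3O)c2n1` gives > 20000 nM, which is a limit and not a number. Compound 3 `Cc1nc(N)c2c(-c3ccco3)cn([C@@H]3O[C@H](CO)[C@@H](O)[C@H]3O)c2n1` gives > 20000 nM, again only a limit, so its place on the scale is not fixed. Compound 4 `C#Cc1cn([C@@H]2O[C@H](CO)[C@@H](O)[C@H]2O)c2nc(C)nc(N)c12` carries ethynyl in place of furan-2-yl on an aromatic carbon. For the measured compounds named here, no measured step covers this change. The only one, a step that the two limits leave unreadable from compound 2 to compound 3, concerns methyl in place of amino on an aromatic carbon and has no readable size. Any number for compound 4 would have to fall on the stronger side of that limit, and a further limit remains quite possible. The expected step is an at least 4.0-fold lower number from compound 3 to compound 4 (0.60 log units; beyond the scatter), towards stronger inhibition. For compound 4 the estimate is 5000 nM, with an expected range of 300 nM to 20000 nM.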

Compound 4, half-maximal inhibitory concentration: > 20000 nM
Compound 4: a limit, no number (the forecaster's own chance of this, stated with the estimate: 45%); at least 4.0-fold (0.60 log units) between middle value and limit.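

In this assay, for the compounds shown here, compound 4 gives > 20000 nM, a limit and not a number, as compound 3 also gives only a limit, so no step between compound 3 and compound 4 can be read. From the compounds shown here alone, how ethynyl in place of furan-2-yl changes inhibition therefore stays open.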